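The compounds below may be only part of what the source reports. "The series", "measured", "known", "first", "only" and "open" are said of these compounds alone.

Compound 1 `O=S(=O)(c1cccc(F)c1)c1cnc2c(F)cccc2c1-c1cccc(Cl)c1` is the anchor of this comparison. In an ADME assay on microsomes from liver (Homo sapiens) for metabolic stability, tested at 2.5 uM (on this read-out higher numbers stand for fast clearance and lower numbers for slow clearance), compound 1 gives 0.56 mL/min, the lowest of the two numbers recorded so far. Within the data shown here, the only other measured compound is compound 2 `Cc1ccc(S(=O)(=O)c2cnc3c(F)cccc3c2-c2cccc(Cl)c2)cc1F`, which carries a methyl in place of hydrogen on an aromatic carbon and in this assay gives 3.18 mL/min; the step of a 5.7-fold higher number from compound 1 to compound 2 (0.75 log units; beyond the scatter) is the one measured change in this set.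

The new compound is compound 3 `COc1cccc(-c2c(S(=O)(=O)c3cccc(F)c3)cnc3c(F)cccc23)c1`. Its difference from compound 1 is methoxy in place of chloro on an aromatic carbon. Among the measured compounds shown here, no measured step covers a methoxy in place of chloro on an aromatic carbon, and the step from compound 1 to compound 2 concerns a different ring and a different group, so it does not bear directly on this change. The expectation for compound 3 therefore rests on compound 1 alone, allowing for a shift that may not exceed the scatter, with an expected step of a 1.8-fold higher number from compound 1 to compound 3 (0.25 log units; within the scatter). Compound 3 is estimated to give 1 mL/min in this assay, within a range of 0.4 mL/min to 2.5 mL/min.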

Compound 3, intrinsic clearance in a liver preparation (reported as CLH), per the amount of preparation that the assay uses: 2.6 mL/min
Beside the measured number, compound 3's estimate is 2.6-fold (0.41 log units) below it; the whole stated range lies below it.
By their numbers in this assay, from the lowest: compound 1; then compounds 3 and 2 (each within the scatter of the next).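

Among these compounds, the swap of 3-chlorophenyl to 3-methoxyphenyl is the first measured change at this place on the shared core, and in this assay it gives a 4.6-fold higher number from compound 1 to compound 3 (0.67 log units; beyond the scatter), so this position is not indifferent to what it carries. Among the compounds shown here, until now the only measured change lay on the other aromatic ring, where the methyl gave a 5.7-fold higher number from compound 1 to compound 2 (0.75 log units; beyond the scatter); across these two single changes, compound 1 keeps the lowest number, and each change moves the read-out beyond the scatter. The compounds shown offer no evidence on what lies behind the step from chloro to methoxy.

As far as these compounds go, what stays open is whether this higher number belongs to methoxy in particular or would follow other replacements of chloro at this place, such as an amine, a nitrile or a longer chain like ethoxy. Also open, from the compounds shown here alone, is whether methoxy in place of chloro would give a step of similar size on compound 2, which carries the added methyl on its other ring, since the two changes are seen here only apart.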